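The source may report more compounds than this note shows. Statements on the series, on what has been measured and on what is new or still open speak of the compounds shown alone.

Of the compounds shown here, three sharing one core have been measured in a functional assay on DU-145 cells (Homo sapiens) for antiproliferative activity, read by CCK-8 assay, with a stated time of 72 h; on this read-out lower numbers stand for stronger inhibition and higher numbers for weaker inhibition. Compound 1 `Cc1cc(Nc2cc(N3CCN(C)CC3)nc(Nc3ccc(Cl)cc3)n2)n[nH]1` gives 2240 nM. Compound 2 `Cc1cc(Nc2cc(N3CCN(C)CC3)nc(Nc3cccc([N+](=O)[O-])c3)n2)n[nH]1` gives 1340 nM, and compound 3 `Cc1cc(Nc2cc(N3CCN(C)CC3)nc(Nc3ccc(S(N)(=O)=O)cc3)n2)n[nH]1` gives 926 nM. Compound 2 thus stands second highest of the three numbers, with the nearest neighbour being compound 3 and the furthest compound 1, and both of its steps lie within the scatter: a 1.7-fold lower number from compound 1 to compound 2 (0.22 log units; within the scatter) and a 1.4-fold lower number from compound 2 to compound 3 (0.16 log units; within the scatter). Among the compounds with values here, only the step from compound 1 to compound 3 reaches beyond the scatter, a 2.4-fold lower number from compound 1 to compound 3 (0.38 log units; beyond the scatter), and it is modest.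

Compound 4 `COc1ccc(Nc2nc(Nc3cc(C)[nH]n3)cc(N3CCN(C)CC3)n2)cc1` differs from compound 2 in one place: 4-methoxyphenyl in place of 3-nitrophenyl on a nitrogen on an aromatic ring. Within the data shown here, the steps that bear on this change are those that also swap the aromatic ring on this nitrogen, namely the step from compound 1 to compound 2 and the step from compound 2 to compound 3, and both stayed within the scatter. On that basis no step beyond the scatter is expected in this assay for compound 4, and the estimate is a 1.1-fold higher number from compound 2 to compound 4 (0.05 log units; within the scatter). For compound 4 the expected value in this assay is 1500 nM, with a range from 500 nM to 4500 nM.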

Compound 4, half-maximal inhibitory concentration: 5050 nM
Beside the measured number, compound 4's estimate is 3.4-fold (0.53 log units) below it; measured number outside the range, above it.
By their numbers in this assay, from the lowest: compounds 3, 2 and 1 (each within the scatter of the next, the first and the last beyond it); then compound 4.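

The ring on this nitrogen turns out to be less forgiving than the first three compounds suggested, since 4-methoxyphenyl brings a clear loss in this assay against every other group tried here: a 3.8-fold higher number from compound 2 to compound 4 (0.58 log units; beyond the scatter), a 5.5-fold higher number from compound 3 to compound 4 (0.74 log units; beyond the scatter) and a 2.3-fold higher number from compound 1 to compound 4 (0.35 log units; beyond the scatter). Within the data shown here, compound 4 is therefore the weakest of the four, and the last two steps show that the group carried on the same 4-substituted phenyl ring can matter, since swapping only that group moves the number beyond the scatter in both cases. Nothing measured here accounts for why methoxy behaves this way.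

The step from the 3-nitrophenyl compound changes both the group and the way the ring is substituted, so the compounds shown cannot separate these two effects, and 3-methoxyphenyl would be the direct test. As far as these compounds go, it also remains open how a 4-substituted ring carrying an amine, a carboxylic acid or a longer chain such as ethoxy would compare with 4-methoxyphenyl and 4-sulfamoylphenyl.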